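The source may report more compounds than this note shows. Statements on the series, on what has been measured and on what is new or still open speak of the compounds shown alone.

Measured so far in a functional assay on HT-29 cells (Homo sapiens) for antiproliferative activity, read by MTT assay, with a stated time of 72 h; on this read-out lower numbers stand for stronger inhibition and higher numbers for weaker inhibition:
- compound 1 `COc1cc2c(Oc3ccc(NC(=O)c4cc(-c5ccc(F)cc5)on4)cc3)ccnc2cc1OCCCN1CCC(C)CC1` gives 24600 nM
- compound 2 `COc1cc2nccc(Oc3ccc(NC(=O)c4ncc(-c5ccc(F)cc5)o4)cc3)c2cc1OC` gives > 100000 nM
- compound 3 `COc1cc2c(Oc3ccc(NC(=O)c4ncc(-c5ccc(F)cc5)o4)cc3)ccnc2cc1OCCCN1CCC(C)CC1` gives 1890 nM

Within the data shown here, compound 2 gives only a limit in this assay, not a number; it is the one value of the three that sits at the limit of > 100000 nM in this assay, at which 1 of the 3 values shown sits. Compound 4 `COc1cc2nccc(Oc3ccc(NC(=O)c4cc(-c5ccc(F)cc5)on4)cc3)c2cc1OC` has not yet been measured. It differs from compound 2 in one place: 5-(4-fluorophenyl)-1,2-oxazol-3-yl in place of 5-(4-fluorophenyl)-1,3-oxazol-2-yl on a carbonyl carbon.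

Among the measured compounds shown here, two measured steps bear on this. The same exchange of the five-membered ring, taken in the opposite direction, is seen between compound 1 and compound 3: a 13-fold lower number from compound 1 to compound 3 (1.11 log units; beyond the scatter). The other step shows that the side chain on the saturated chain carbon bound to an oxygen on an aromatic ring matters greatly, an at least 52-fold lower number from compound 2 to compound 3 (1.72 log units; beyond the scatter), which is what leaves compound 2 at the limit in the first place.

Reversing the ring step of compound 1 to compound 3 therefore points to a higher number from compound 2 to compound 4, and since compound 2 already gives only a limit, compound 4 is expected to return a limit as well. The expected change is a step that the limit leaves unreadable from compound 2 to compound 4. Compound 4 is estimated at 400000 nM, in a range from 100000 nM to 2000000 nM.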

Compound 4, half-maximal inhibitory concentration: > 100000 nM
Compound 4 ended at the assay's limit; the forecaster's own chance of this, stated with the estimate: 92%; the middle value does not contradict the limit.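

Working notes on the series: in this assay, the exchange of 5-(4-fluorophenyl)-1,3-oxazol-2-yl for 5-(4-fluorophenyl)-1,2-oxazol-3-yl on a carbonyl carbon gives no readable step without the 2-(4-methylpiperidin-1-yl)ethyl group, as both compound 2 and compound 4 stand at a limit and the step between them cannot be read. The side chain change now has a second pair: hydrogen in place of 2-(4-methylpiperidin-1-yl)ethyl gives an at least 4.0-fold higher number from compound 1 to compound 4 (0.60 log units; beyond the scatter), so the loss of this group raises the number with either five-membered ring on the carbonyl carbon. The two pairs agree in direction, while their sizes cannot be ranked: the same change on two cores in this assay, an at least 52-fold lower number (1.72 log units; beyond the scatter) from compound 2 to compound 3 and an at least 4.0-fold lower number (0.60 log units; beyond the scatter) from compound 4 to compound 1; the limit leaves it open whether they differ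

Still open, from the compounds shown here alone, is whether the ring exchange makes any difference on the core without the side chain, and the limit hides this for both compounds: the limit of > 100000 nM in this assay, at which 2 of the 4 values shown sit. Also open is how much of the side chain is needed, for example whether a morpholine or a dimethylamine at the end of the chain, or a longer chain carrying the 4-methylpiperidine, keeps the numbers of compound 1 and compound 3 or takes them further down.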